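A few compounds are considered here, and "the series" means these few. Any claim that something is new, unique, unknown or untested is made for them only; others in the source may bear on it.

Measured compounds:
compound 1, `Cc1cccc(Nc2nccc(-c3cccs3)n2)c1`: 300 nM
compound 2, `COc1cccc(Nc2nccc(-c3ccco3)n2)c1`: 400 nM
compound 3, `COc1cccc(Nc2nccc(-c3ccc(C)o3)n2)c1`: 1500 nM

All three were tested in a functional assay for inhibition, with Homo sapiens as the target; a lower number here means a stronger inhibitor, a higher number a weaker inhibitor. Compound 1 gives the lowest number of the three, but compound 2 sits within the scatter of it, so no order between these two can be read from the data. Compound 3 lies beyond the scatter from compound 1, and its value is the highest of the set. The difference between the core of compound 1 and that of compound 2 is not broken down here.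

Compounds 2 and 3 differ in one place: methyl in place of hydrogen on an aromatic carbon. That change produced a 3.8-fold higher number from compound 2 to compound 3 (0.57 log units; beyond the scatter), a modest loss that lies beyond the scatter.

Compound 4, `Cc1cc(C)cc(Nc2nccc(-c3cccs3)n2)c1`, has not yet been measured. It differs from compound 1 by methyl in place of hydrogen on an aromatic carbon. This is the same kind of change as from compound 2 to compound 3, but not the same: there the methyl entered on a five-membered aromatic ring with one oxygen, next to the ring oxygen, two ring bonds from the ring atom that bears a large group; here it enters on a six-membered aromatic ring of carbon only, meta to a large group and meta to a methyl group. Going by the values given here, only one such step has been measured, and it concerns a different ring, so the precedent is weak. Among the compounds with values here, compound 4 is expected to show a 1.5-fold higher number from compound 1 to compound 4 (0.18 log units; within the scatter), a step smaller than a 3.8-fold higher number from compound 2 to compound 3 (0.57 log units; beyond the scatter) and close to the scatter, because the single measured step is a 3.8-fold higher number from compound 2 to compound 3 (0.57 log units; beyond the scatter) on another ring. The estimate for compound 4 in this assay is 450 nM, with a range from 200 nM to 1200 nM.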

Compound 4, half-maximal inhibitory concentration: 4300 nM
Compound 4: the middle estimate sits 9.6-fold (0.98 log units) below what was measured; measured number outside the range, above it.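

In this assay, methyl in place of hydrogen on an aromatic carbon of the six-membered aromatic ring of carbon only gave a 14-fold higher number from compound 1 to compound 4 (1.16 log units; beyond the scatter), a large loss. Both steps measured for this change in the series raise the number, but their sizes differ, so the size of the loss did not carry over from one core to the other: the same change on two cores in this assay, a 3.8-fold higher number (0.57 log units; beyond the scatter) from compound 2 to compound 3 and a 14-fold higher number (1.16 log units; beyond the scatter) from compound 1 to compound 4, 3.8-fold (0.58 log units) apart, beyond the scatter of two such steps This does not show that the core alone sets the size of the step, since the methyl also enters a different ring in each pair, and two steps cannot separate the influence of the core from that of the ring or the place of substitution; nor do they give a rule that would hold for any further core in the series.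

The compounds shown leave open how the same methyl change would behave on one ring carried by two different cores, which would be the cleaner comparison of the two effects. They also leave open whether a chlorine, an amine or a carboxylic acid in place of that hydrogen would give a step of similar size to the methyl or a quite different one.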